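A few compounds are considered here, and "the series" means these few. Any claim that something is new, unique, unknown or untested is made for them only; others in the source may bear on it.

Measured in a functional assay on KB cells (Homo sapiens) for cytotoxicity, read by spectrophotometry and crystal violet staining; on this read-out higher numbers stand for weaker inhibition and lower numbers for stronger inhibition:
- Compound 1 `CC(=O)N/N=C/c1c(Cl)n(C2O[C@H](CO)[C@@H](O)[C@H]2O)c2cc(Cl)c(Cl)cc12`: 9000 nM
- Compound 2 `N/C(=N\O)c1c(Cl)n(C2O[C@H](CO)[C@@H](O)[C@H]2O)c2cc(Cl)c(Cl)cc12`: > 100000 nM, a limit of the assay and not a number

Compound 2 stands at the limit of > 100000 nM in this assay, at which 1 of the 2 values shown sits, so no exact number is known for it.

Compound 3 `N#Cc1c(Cl)n(C2O[C@H](CO)[C@@H](O)[C@H]2O)c2cc(Cl)c(Cl)cc12` keeps the shared core of compound 2 but carries cyano in place of a group of 4 heavy atoms, on an aromatic carbon: a group of 2 heavy atoms (1 carbon, 1 nitrogen; no ring) in place of a group of 4 heavy atoms (1 carbon, 2 nitrogen, 1 oxygen; no ring), on an aromatic carbon.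

Among the measured compounds shown here, one measured step bears on this change, as it concerns the same aromatic carbon. That step is an at least 11-fold higher number from compound 1 to compound 2 (1.04 log units; beyond the scatter), and it is large. It shows that the group at this place can move the number in this assay strongly. Compound 1, at 9000 nM, also shows that the shared core can give a measurable number. A sizeable shift towards a lower number is therefore expected, although a second reading at the limit remains possible.

The expected change is an at least 4.0-fold lower number from compound 2 to compound 3 (0.60 log units; beyond the scatter). For compound 3 the estimated value is 25000 nM, with an expected range from 4000 nM to 100000 nM.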

Compound 3, half-maximal inhibitory concentration: 65000 nM
Compound 3: middle estimate off by 2.6-fold (0.41 log units), on the low side; the range from low to high includes it.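

In this assay, the cyano group gives an exact reading at this aromatic carbon, so two different groups on the shared core can now be compared as numbers and not against a limit. That comparison is a 7.2-fold higher number from compound 1 to compound 3 (0.86 log units; beyond the scatter), which shows that a group at this place can separate two measured values by more than the scatter, whereas the earlier step set only a floor. Compared with the group that leaves, the change to cyano is an at least 1.5-fold lower number from compound 2 to compound 3 (0.18 log units; that floor lies within the scatter), so the shift itself is not established, and the value of compound 2 is a limit and not a number: the limit of > 100000 nM in this assay, at which 1 of the 3 values shown sits.

The compounds shown leave open whether the gap between compound 1 and compound 3 goes with the size of the group at this place, with its hydrogen-bond donors, or with neither. They also do not tell how a carboxylic acid, an amine or a longer chain on this aromatic carbon would read, or whether any group here can reach a lower number than compound 1 gives, 9000 nM.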